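The source may hold more compounds than are shown below. What is called first, only, known or untested is meant among the compounds shown, and "the series" means these compounds.

Working notes, measured so far in a functional assay on NCI-H460 cells (Homo sapiens) for inhibition, read by MTT assay, with a stated time of 24 h, tested at 1 ug/mL; a higher number here means more inhibition of growth at the concentration tested, a lower number less inhibition of growth:

- compound 1 `CC(=O)SCCC(CCCCC(=O)O)SC(C)=O`: 9.89%
- compound 2 `CC(=O)SCCC(CCCCC(=O)Nc1ccccc1)SC(C)=O`: 13.1%
- compound 3 `CC(=O)SCCC(CCCCC(=O)Nc1cccc(Cl)c1)SC(C)=O`: 0.31%

Not yet measured: compound 4 `CC(=O)SCCC(CCCCC(=O)Nc1ccc(Cl)cc1)SC(C)=O`.

Within the data shown here, compound 3 is separated from only one of its two neighbours. The data give a number 12.8 percentage points lower from compound 2 to compound 3 (beyond the scatter), but also a number 9.6 percentage points lower from compound 1 to compound 3 (within the scatter). The remaining comparison is a number 3.2 percentage points higher from compound 1 to compound 2 (within the scatter), so all the numbers in this assay lie close together.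

The next change is 4-chlorophenyl in place of 3-chlorophenyl on an amide-type nitrogen; in words, 4-chlorophenyl in place of 3-chlorophenyl on an amide-type nitrogen. Among the measured compounds shown here, no measured step moves the chloro group, so the data bear on this change only indirectly. The closest measured step is a number 12.8 percentage points lower from compound 2 to compound 3 (beyond the scatter), which introduces the chloro group, chloro in place of hydrogen on an aromatic carbon. It says nothing about where that group sits.

From the compounds shown here alone, a step beyond the scatter is therefore not expected, and the direction stays open. A slight upward lean is allowed only since compound 3, at 0.31%, has little room beneath it. The estimated step is a number 5.7 percentage points higher from compound 3 to compound 4 (within the scatter). For compound 4 the expected value is 6%, with an estimated range from 0% to 16%.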

Compound 4, percent growth inhibition at one concentration: 15.4%
The estimate for compound 4 lay 9.4 percentage points below the measured number, and the stated range covers the measured number.
By their numbers in this assay, from the lowest: compounds 3, 1, 2 and 4 (each within the scatter of the next, the first and the last beyond it).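

In this assay, among these compounds, moving the chloro group alone, with 4-chlorophenyl in place of 3-chlorophenyl on an amide-type nitrogen, gives a number 15.1 percentage points higher from compound 3 to compound 4 (beyond the scatter) and is the first measured sign that its placement matters. The loss seen in a number 12.8 percentage points lower from compound 2 to compound 3 (beyond the scatter) therefore does not follow from the chloro group as such: with 4-chlorophenyl, chloro in place of hydrogen gives a number 2.3 percentage points higher from compound 2 to compound 4 (within the scatter) and the change from the free acid to the (4-chlorophenyl)amino amide gives a number 5.5 percentage points higher from compound 1 to compound 4 (within the scatter) and neither step leaves the scatter. Among these compounds, only compound 3 stands apart from any other, and nothing available here accounts for the difference between the two chloro placements.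

From the compounds shown here alone, whether a methoxyphenyl, a pyridyl or a benzyl on the amide-type nitrogen would group with compound 3 or with compound 4 stays open, as does the effect of a longer chain between the amide carbonyl and the sulfur-bearing carbon. Going by these compounds, all four compounds also share both thioacetate groups, so the contribution of a free thiol in their place remains unknown.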